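Acetyl on the Phenyl Ring of Compound 3

This account rests on a few compounds, and the source may have more. Where it says the series, first, only, none or still open, it means among the compounds named here.

In a functional assay on HCT-116 cells (Homo sapiens) for inhibition, read by CCK-8 assay, with a stated time of 48 h (on this read-out lower numbers stand for stronger inhibition and higher numbers for weaker inhibition), compound 1 (`COc1cc(-c2ccnc3cc(-c4cn(CO)c5ccccc45)nn23)cc(OC)c1OC`) reads 128 nM and compound 2 (`Cn1ccc2cc(-c3cc4nccc(-c5ccc(F)cc5)n4n3)ccc21`) reads 2160 nM while compound 3 (`COc1cc(-c2ccnc3cc(-c4ccccc4)nn23)cc(OC)c1OC`) reads 3880 nM on the same scale. Compound 3 thus sits within the scatter of compound 2 and well above compound 1. Compound 4 (`COc1cc(-c2ccnc3cc(-c4ccc(C(C)=O)cc4)nn23)cc(OC)c1OC`) comes from compound 3 through one change, acetyl in place of hydrogen on an aromatic carbon, para to a large group (acetyl in place of hydrogen on an aromatic carbon). Going by the values given here, no two measured compounds differ in only one place, so the data offer no direct guide to this change. A modest move toward lower numbers is expected in this assay and it may stay within the scatter. The estimated step is a 1.7-fold lower number from compound 3 to compound 4 (0.23 log units; within the scatter) at the middle of the range. For compound 4 the estimate is 2300 nM with an expected range from 700 nM to 7000 nM in this assay.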

Compound 4, half-maximal inhibitory concentration: 4390 nM
For compound 4 the middle estimate is 1.9-fold (0.28 log units) below the measured one; the range from low to high includes it.
By their numbers in this assay, from the lowest: compound 1; then compounds 2, 3 and 4 (each within the scatter of the next, the first and the last beyond it).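

In this assay, going by these compounds alone, the change from phenyl to 4-acetylphenyl gives a 1.1-fold higher number from compound 3 to compound 4 (0.05 log units; within the scatter) and is the first step between compounds differing in one place. This aromatic carbon of compound 3 therefore carries an acetyl with no change beyond the scatter, so the added group neither gains nor loses anything measurable here. Nothing available accounts for this result. As far as these compounds go, whether an amine or a carboxylic acid at the same place would read differently remains open, as does whether acetyl would have a similar effect on compound 1.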